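Cyclohexyl for octyl on the acyl-linked oxygen of compound 1

The compounds below may be only part of what the source reports. "The series", "measured", "known", "first", "only" and "open" are said of these compounds alone.

Measured so far:
compound 1 `CCCCCCCCOC(=O)C(O)Cn1cnc2c(N)ncnc21`: 100 ug/mL
compound 2 `CCCCOC(=O)C(O)Cn1cnc2c(N)ncnc21`: 200 ug/mL

In a functional assay on PRK cells (Oryctolagus cuniculus) for cytotoxicity (a higher number here means that more compound is tolerated, a lower number that less compound is tolerated), compound 1 gives the lowest of the two numbers, and its nearest neighbour is compound 2 with a 2.0-fold higher number from compound 1 to compound 2 (0.30 log units; within the scatter). Compound 3 `Nc1ncnc2c1ncn2CC(O)C(=O)OC1CCCCC1` is the unmeasured member: cyclohexyl in place of octyl on an oxygen next to a carbonyl group. Going by the values given here, the only step that bears on this change is the shortening of the same chain, a 2.0-fold higher number from compound 1 to compound 2 (0.30 log units; within the scatter), which stayed within the scatter. A cyclohexyl group is expected to behave like the measured chains here, so the estimated step of a 1.4-fold higher number from compound 1 to compound 3 (0.15 log units; within the scatter) is small. Compound 3 is therefore expected to give about 140 ug/mL, with a range from 70 ug/mL to 300 ug/mL.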

Compound 3, minimum cytotoxic concentration: 100 ug/mL
The estimate for compound 3 lay 1.4-fold (0.15 log units) above the measured number, and the stated range covers the measured number.
By their numbers in this assay, from the lowest: compounds 1, 3 and 2 (each within the scatter of the next).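

Replacing the open octyl chain with the cyclohexyl ring on this oxygen gives, in this assay, no change at the digits printed from compound 1 to compound 3 (within the scatter). Comparing the ring with the shorter butyl chain gives a 2.0-fold lower number from compound 2 to compound 3 (0.30 log units; within the scatter), so among these three compounds, a ring at this position behaves no differently from either open chain. No other measurement is available to explain this result.

Going by these compounds, it remains open whether a chain longer than octyl, a phenyl ring or a group carrying an amine or a carboxylic acid would also stay within the scatter.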